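This account rests on a few compounds, and the source may have more. Where it says the series, first, only, none or still open, it means among the compounds named here.

Measured in an ADME assay on HEL cells (Homo sapiens), read by cell counting, with a stated time of 3 days; a lower number here means that less compound is tolerated, a higher number that more compound is tolerated:
- Compound 1 `COc1cc(C#CC#Cc2cn([C@H]3C[C@H](O)[C@@H](CO)O3)c(=O)[nH]c2=O)cc(OC)c1`: > 100000 nM, a limit
- Compound 2 `Nc1ccc(C#CC#Cc2cn([C@H]3C[C@H](O)[C@@H](CO)O3)c(=O)[nH]c2=O)cc1`: > 100000 nM, a limit
- Compound 3 `O=c1[nH]c(=O)n([C@H]2C[C@H](O)[C@@H](CO)O2)cc1C#CC#Cc1ccc(OC(F)(F)F)cc1`: 55000 nM

Compound 2 has no exact number and sits at the limit of > 100000 nM in this assay, at which 2 of the 3 values shown sit. Compound 4 `O=c1[nH]c(=O)n([C@H]2C[C@H](O)[C@@H](CO)O2)cc1C#CC#CCC1CCCC1` is unmeasured and carries cyclopentylmethyl in place of 4-aminophenyl on a triple-bonded carbon. Two measured steps change a group at this same end of the molecule. The swap of 3,5-dimethoxyphenyl for 4-aminophenyl gave a step that the two limits leave unreadable from compound 1 to compound 2. Trifluoromethoxy in place of amino gave an at least 1.8-fold lower number from compound 2 to compound 3 (0.25 log units; that floor lies within the scatter). Neither step shows a clear change, so only a small downward move is expected in this assay, perhaps none beyond the scatter. The expected change is an at least 1.4-fold lower number from compound 2 to compound 4 (0.15 log units; that floor lies within the scatter). For compound 4 the estimate is 70000 nM, with an expected range of 30000 nM to 100000 nM.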

Compound 4, half-maximal cytotoxic concentration: 89000 nM
Beside the measured number, compound 4's estimate is 1.3-fold (0.10 log units) below it, within the range that was stated.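

In this assay, putting a non-aromatic carbon ring in place of the aromatic groups on the triple-bonded carbon gave an at least 1.1-fold lower number from compound 2 to compound 4 (0.05 log units; that floor lies within the scatter) and an at least 1.1-fold lower number from compound 1 to compound 4 (0.05 log units; that floor lies within the scatter). The earlier compounds shown here carried only aromatic rings at this place, and compound 4 shows that cyclopentylmethyl, with no hydrogen-bond donor or acceptor, brings no clear change from them. The true size of both steps stays unknown, as each starts from a limit: the limit of > 100000 nM in this assay, at which 2 of the 4 values shown sit.

What the compounds shown leave open is whether a carboxylic acid or a longer open carbon chain at this place would move the number beyond the scatter.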